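Pyrazine hydrazones on murine macrophages: cytotoxicity notes

The compounds below may be only part of what the source reports. "The series", "measured", "known", "first", "only" and "open" are said of these compounds alone.

Measured so far in an ADME assay on J774 cells (Mus musculus) for cytotoxicity, read by MTT assay, with a stated time of 48 h, tested at 50 ug/mL; on this read-out higher numbers stand for a weaker effect at the one concentration tested and lower numbers for a stronger effect:

- compound 1 `O=C(N/N=C/c1ccc(F)cc1)c1cnccn1` gives 78%
- compound 2 `N#Cc1cccc(/C=N/NC(=O)c2cnccn2)c1` gives 100%

Compound 1 stands lowest of the two numbers in hand. Its nearest neighbour is compound 2, whose number lies higher by a gap beyond the usual scatter, so compound 1 shows the stronger effect of the pair in this assay, while compound 2 shows essentially no effect at the single concentration used. Among the measured compounds shown here, no step between a directly comparable pair has been worked out, so nothing yet tells how a single replacement on the aromatic ring moves this read-out.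

The next compound, compound 3 `CN(C)c1ccc(/C=N/NC(=O)c2cnccn2)cc1`, differs from compound 1 only at one place on the ring: dimethylamino in place of fluoro on an aromatic carbon. For the measured compounds named here, no measured step in this assay speaks to this kind of exchange, and the two values in hand give no lead on it either. The expectation is therefore a step from compound 1 to compound 3 of no more than the scatter, if anything leaning towards a weaker effect; that expected step is a number 7 percentage points higher from compound 1 to compound 3 (within the scatter). For compound 3 the value expected in this assay is 85%, within a range from 65% to 100%.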

Compound 3, a percentage reported as activity, at one concentration (the size of the read-out at that concentration, not a potency): 93%
Compound 3: the middle estimate sits 8 percentage points below what was measured, and the stated range covers the measured number.
By their numbers in this assay, from the lowest: compound 1; then compounds 3 and 2 (each within the scatter of the next).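

Among the compounds shown here, exchanging fluoro for dimethylamino on an aromatic carbon, para to a large group, gives the first readable step in this assay with a number 15 percentage points higher from compound 1 to compound 3 (beyond the scatter) as a modest move towards a weaker effect at the one concentration tested. This place on the ring is therefore not silent: a single exchange of one uncharged, ring-free group for another moves the read-out beyond the scatter, which the two earlier values alone could not show, as compound 1 and compound 2 differ in more than one place. Nothing in hand bears on what lies behind this step.

As far as these compounds go, with one step, it remains open whether the stronger effect of compound 1 belongs to fluoro in particular or would also appear with other small groups at this place, such as chloro or methoxy. From the compounds shown here alone, it also remains open whether a primary amine, a carboxylic acid or a longer chain here would read close to compound 1 or close to compound 3, and whether the step holds at any other concentration.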